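From Compound 2 to Compound 3: a Longer Selenium Substituent

This account rests on a few compounds, and the source may have more. Where it says the series, first, only, none or still open, it means among the compounds named here.

Compound 2 `COc1ccc(N(C)c2nc(C)nc3ccccc23)cc1[Se]C` stands at the lowest of the two numbers seen so far: in a functional assay on HCT-116 cells (Homo sapiens) for inhibition, read by MTT assay, with a stated time of 48 h (a higher number here means a weaker inhibitor, a lower number a stronger inhibitor), compound 2 gives 28 nM, whereas compound 1 `COc1ccc(N(C)c2nc(C)nc3ccccc23)cc1OCCCCCC[Se]C#N` gives 6180 nM. Going by the values given here, compound 3 `COc1ccc(N(C)c2nc(C)nc3ccccc23)cc1C[Se]C#N` differs from compound 2 in one place: a group of 4 heavy atoms (2 carbon, 1 nitrogen, 1 selenium; no ring) in place of a group of 2 heavy atoms (1 carbon, 1 selenium; no ring), on an aromatic carbon The only measured step bearing on this change is a 220-fold lower number from compound 1 to compound 2 (2.34 log units; beyond the scatter), where a far longer chain ending in the same triple bond was removed. As the group entering here is shorter than that chain, a rise in this assay is expected, a 21-fold higher number from compound 2 to compound 3 (1.33 log units; beyond the scatter), smaller than a 220-fold lower number from compound 1 to compound 2 (2.34 log units; beyond the scatter). Compound 3 is estimated at 600 nM, with a range from 150 nM to 3000 nM.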

Compound 3, half-maximal inhibitory concentration: 113 nM
Beside the measured number, compound 3's estimate is 5.3-fold (0.73 log units) above it; measured number outside the range, below it.
By their numbers in this assay, from the lowest: compound 2; then compound 3; then compound 1.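

At this aromatic carbon, ortho to a methoxy group, a selenium group ending in a nitrile is far better accommodated when short: in this assay, the shorter group gives a 55-fold lower number from compound 1 to compound 3 (1.74 log units; beyond the scatter). Even so, the smaller group of compound 2 keeps the lowest number, with a 4.0-fold higher number from compound 2 to compound 3 (0.61 log units; beyond the scatter), so the short nitrile group brings no gain over it. Nothing available explains either step. The compounds shown leave open whether the nitrile or the longer group accounts for this rise, and how a chain of intermediate length ending in the same nitrile would fall between compound 3 and compound 1.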